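From 3-methoxyphenyl to 4-(trifluoromethyl)phenyl on the shared core

This account rests on a few compounds, and the source may have more. Where it says the series, first, only, none or still open, it means among the compounds named here.

Within the data shown here, in a functional assay on L1210 cells (Mus musculus) for antiproliferative activity (on this read-out higher numbers stand for weaker inhibition and lower numbers for stronger inhibition), compound 2 `COc1cccc(-c2cc(N)c(C(=O)c3cc(OC)c(OC)c(OC)c3)s2)c1` gives 22 nM, the lower of the two numbers so far, while compound 1 `COc1cc(C(=O)c2sc(-c3ccc(Br)cc3)cc2N)cc(OC)c1OC` gives 100 nM. Compound 3 `COc1cc(C(=O)c2sc(-c3ccc(C(F)(F)F)cc3)cc2N)cc(OC)c1OC` carries 4-(trifluoromethyl)phenyl in place of 3-methoxyphenyl on an aromatic carbon. Among the measured compounds shown here, only one measured step bears on this, the modest 4.5-fold lower number from compound 1 to compound 2 (0.66 log units; beyond the scatter), which brought in the 3-methoxyphenyl that compound 3 gives up. A step of similar size towards a higher number is therefore expected in this assay, though a single step is thin evidence. The estimated step is a 5.0-fold higher number from compound 2 to compound 3 (0.70 log units; beyond the scatter). Compound 3 is expected at 110 nM, with a range of 40 nM to 350 nM.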

Compound 3, half-maximal inhibitory concentration: 370 nM
Beside the measured number, compound 3's estimate is 3.4-fold (0.53 log units) below it; measured number outside the range, above it.
By their numbers in this assay, from the lowest: compound 2; then compound 1; then compound 3.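

In this assay, among these compounds, the group on the aromatic carbon next to the ring sulfur has a larger effect than the earlier compounds showed: 4-(trifluoromethyl)phenyl in place of 3-methoxyphenyl gives a 17-fold higher number from compound 2 to compound 3 (1.23 log units; beyond the scatter). Trifluoromethyl in place of bromo gives a 3.7-fold higher number from compound 1 to compound 3 (0.57 log units; beyond the scatter), so 4-bromophenyl and 4-(trifluoromethyl)phenyl are not interchangeable here. Nothing available explains either step. The compounds shown leave open whether the methoxy group itself or its place on the phenyl ring sets the low number of compound 2. They also leave open how 4-methoxyphenyl or a phenyl ring carrying an amine or a carboxylic acid would compare.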